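The source may hold more compounds than are shown below. What is called first, only, known or untested is meant among the compounds shown, and "the series" means these compounds.

Within the data shown here, compound 1 `CC(C)c1onc(-c2c(Cl)cccc2Cl)c1COc1ccc(-c2nc3ccc(C(=O)O)cc3n2C2CC2)cc1` is one of three compounds measured in an assay on HEK-293T cells for antagonist activity at vitamin D3 receptor (Homo sapiens), read by a luciferase reporter, with a stated time of 24 h (a lower number here means a stronger inhibitor, a higher number a weaker inhibitor), and in it compound 1 gives 3200 nM. Two other compounds sit near it. Compound 2 `CC(C)c1onc(-c2c(Cl)cccc2Cl)c1COc1ccc(-c2nc3ccc(C(=O)O)cc3n2C)cc1Cl` is measured in this assay at 2450 nM, and compound 3 `CC(C)c1onc(-c2c(Cl)cccc2Cl)c1COc1ccc(-c2nc3ccc(C(=O)O)cc3n2C)c(Cl)c1` is measured in this assay at 3520 nM. Compound 1 thus stands second highest of the three numbers; its gap to compound 3 and its gap to compound 2 both lie within the usual scatter of this kind of measurement, so none of the three can be set apart from the others on these numbers.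

Compound 4 `CCCC(CCC)n1c(-c2ccc(OCc3c(-c4c(Cl)cccc4Cl)noc3C(C)C)cc2)nc2ccc(C(=O)O)cc21` has not yet been measured in this assay. It differs from compound 1 in one place: 1-propylbutyl in place of cyclopropyl on an aromatic nitrogen. Among the measured compounds shown here, no pair of measured compounds differs in this way, so the size of the step has no measured counterpart here.

Compound 4 is expected to give a step of a 1.6-fold lower number from compound 1 to compound 4 (0.20 log units; within the scatter) in this assay, that is, a slight move toward a lower number, but one that may not clearly exceed the scatter. On that basis, compound 4 is estimated at 2000 nM in this assay, with a range from 600 nM to 6500 nM.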

Compound 4, half-maximal inhibitory concentration: > 10000 nM
Compound 4: no number, only a limit; the forecaster's own chance of this, stated with the estimate: 5%; middle value at least 5.0-fold (0.69 log units) from the limit.
By their numbers in this assay, from the lowest: compounds 2, 1 and 3 (each within the scatter of the next). At a limit, above all of these: compound 4.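

The reading for compound 4 is a limit of the assay and not a number: the limit of > 10000 nM in this assay, at which 1 of the 4 values shown sits.

Even so, it gives this position its first readable step: on the aromatic nitrogen, 1-propylbutyl in place of cyclopropyl gives an at least 3.1-fold higher number from compound 1 to compound 4 (0.49 log units; beyond the scatter) in this assay. Among these compounds, no earlier pair differed at this nitrogen alone, and the three earlier values lay within the scatter of one another, so they gave no sign that a change at this one place could move the number beyond the scatter. The direction is now clear for this single pair, in which the group on the nitrogen goes from a three-membered ring of carbon to an open branched chain with more carbon atoms, though one pair establishes no trend.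

The compounds shown leave open whether the step follows the larger number of carbon atoms, the loss of the ring, or both, and how far the value of compound 4 lies past its limit. A cyclohexyl group or an isopropyl group on the same nitrogen would bear on that question, as would a longer unbranched chain such as n-butyl.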